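A few compounds are considered here, and "the series" means these few. Any claim that something is new, unique, unknown or untested is made for them only; others in the source may bear on it.

Compound 1, `CC(=O)OC[C@H]1O[C@@H](n2cc(-c3cn(Cc4ccc(C(C)(C)C)cc4)nn3)c(=O)[nH]c2=O)C[C@@H]1OC(C)=O`: 97.2%
Compound 2, `CC(=O)OC[C@H]1O[C@@H](n2cc(-c3cc(C)no3)c(=O)[nH]c2=O)C[C@@H]1OC(C)=O`: 96.4%

Both compounds share a sugar-bearing core and were tested in a functional assay on ACHN cells (Homo sapiens) for cytotoxicity, read by sulforhodamine B assay, tested at 10 uM; on this read-out lower numbers stand for less inhibition and higher numbers for more inhibition at the one concentration tested (going by the name of the read-out). In this assay compound 1 gives 97.2% and compound 2 gives 96.4%. On the numbers shown, compound 2 sits alongside compound 1: the gap between them is within the usual scatter, so the two cannot be separated, and the inhibition in this assay is level for the two at the single concentration tested.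

Compound 3, `CC(=O)OC[C@H]1O[C@@H](n2cc(-c3cc(-c4ccc(C(C)C)cc4)no3)c(=O)[nH]c2=O)C[C@@H]1OC(C)=O`, has not been measured yet. It differs from compound 2 in one place: 4-isopropylphenyl in place of methyl on an aromatic carbon. Compound 2 carries a small methyl at that position, while compound 1 carries a much larger benzyl-bearing group on its own five-membered ring and gives a number in this assay that is level with that of compound 2, so a large group at that part of the molecule has not so far gone with a lower number.

The step of a number 1.4 percentage points lower from compound 2 to compound 3 (within the scatter) is therefore expected to be none beyond the scatter, because compound 1 with its own large group also gives 97.2%. Compound 3 is estimated at 95%, with a range from 82% to 100%.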

Compound 3, a percentage reported as inhibition, at one concentration (the size of the read-out at that concentration, not a potency): 90.1%
Compound 3: the middle estimate sits 4.9 percentage points above what was measured; low and high end bracket the measured number.
By their numbers in this assay, from the lowest: compounds 3, 2 and 1 (each within the scatter of the next).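

In this assay, putting 4-isopropylphenyl in place of methyl on this aromatic carbon of the five-membered ring, next to the ring nitrogen, gives a number 6.3 percentage points lower from compound 2 to compound 3 (within the scatter). The earlier compounds shown here showed this position carrying only methyl, so the new information is that it can also hold a much larger group, with a six-membered aromatic ring of carbon only, and the reading still cannot be told apart from that of the methyl compound. Nothing measured here explains why the swap leaves the reading level, and no outside evidence on this position is available.

The compounds shown leave open what a group of a different kind would do at this carbon, such as an amine, a carboxylic acid or a longer alkyl chain, and whether a plain phenyl ring without the isopropyl would read the same. They also leave open whether compound 2 and compound 3 would separate at lower concentrations, since a reading at one concentration is not a potency and cannot show how much of each compound is needed.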